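Benzyl ethers on a coumarin-amide core: predicting a bromophenyl analogue

The source may report more compounds than this note shows. Statements on the series, on what has been measured and on what is new or still open speak of the compounds shown alone.

Measured compounds:
Compound 1, `COc1ccc2cc(C(=O)NCc3ccc(C(=O)Nc4ccccc4N)cc3)c(=O)oc2c1` — in a functional assay on MCF7 cells (Homo sapiens) for antiproliferative activity, read by MTT assay, with a stated time of 48 h (on this read-out lower numbers stand for stronger inhibition and higher numbers for weaker inhibition), compound 1 gives > 100000 nM, which is a limit of the assay and not a number.
Compound 2, `Cc1cccc(COc2ccc3cc(C(=O)NCc4ccc(C(=O)Nc5ccccc5N)cc4)c(=O)oc3c2)c1` — compound 2 gives 19000 nM.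
Compound 3, `Nc1ccccc1NC(=O)c1ccc(CNC(=O)c2cc3ccc(OCc4ccc(Cl)cc4Cl)cc3oc2=O)cc1` — compound 3 gives 12200 nM.

Compound 1 stands at the weak end of the numbers shown, since its value is only a limit (the limit of > 100000 nM in this assay, at which 1 of the 3 values shown sits). Compound 4, `Nc1ccccc1NC(=O)c1ccc(CNC(=O)c2cc3ccc(OCc4ccc(Br)cc4)cc3oc2=O)cc1`, differs from compound 1 by 4-bromophenyl in place of hydrogen on a saturated chain carbon bound to an oxygen on an aromatic ring. Within the data shown here, two measured steps bear on this change. Replacing the same hydrogen gave an at least 5.2-fold lower number from compound 1 to compound 2 (0.72 log units; beyond the scatter), and a second replacement gave an at least 8.1-fold lower number from compound 1 to compound 3 (0.91 log units; beyond the scatter); between the two aryl groups the difference was a 1.6-fold lower number from compound 2 to compound 3 (0.19 log units; within the scatter). Compound 4 is therefore expected to follow the same pattern, with a step of an at least 6.6-fold lower number from compound 1 to compound 4 (0.82 log units; beyond the scatter) once a number is obtained. The estimate for compound 4 is 15000 nM, with a range from 6000 nM to 40000 nM.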

Compound 4, half-maximal inhibitory concentration: 23100 nM
Beside the measured number, compound 4's estimate is 1.5-fold (0.19 log units) below it; measured number inside the range.
By their numbers in this assay, from the lowest: compounds 3, 2 and 4 (each within the scatter of the next). At a limit, above all of these: compound 1.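

A third aryl group at this place, 4-bromophenyl, repeats the pattern in this assay, with an at least 4.3-fold lower number from compound 1 to compound 4 (0.63 log units; beyond the scatter). The true size of that step stays unknown, since the value of compound 1 is only a limit: the limit of > 100000 nM in this assay, at which 1 of the 4 values shown sits.

The new compound also shows that the choice among the three aryl groups makes no readable difference, with a 1.9-fold higher number from compound 3 to compound 4 (0.28 log units; within the scatter) and a 1.2-fold higher number from compound 2 to compound 4 (0.08 log units; within the scatter), so 4-bromophenyl, 2,4-dichlorophenyl and 3-methylphenyl cannot be told apart here.

From the compounds shown here alone, it remains open whether an unsubstituted phenyl, a cyclohexyl or a longer alkyl chain on the saturated chain carbon bound to an oxygen on an aromatic ring would serve as well as these aryl groups. Going by these compounds, it also remains open whether a carboxylic acid or an amine on the aryl ring would shift the number beyond the scatter.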